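The source may hold more compounds than are shown below. What is called first, only, known or untested is meant among the compounds shown, and "the series" means these compounds.

Values in a functional assay on HeLa cells (Homo sapiens) for inhibition, read by MTT assay, with a stated time of 72 h; a higher number here means a weaker inhibitor, a lower number a stronger inhibitor:
- compound 1 `COc1cc(NC(C)CCCNC(=O)NNC(=O)Nc2ccc(Br)cc2)c2ncccc2c1`: 101000 nM
- compound 2 `COc1cc(NC(C)CCCNC(=O)Nc2ccc(C(F)(F)F)cc2)c2ncccc2c1`: 8300 nM

Compound 2 has the lower of the two numbers. Compound 3 `COc1cc(NC(C)CCCNC(=O)Nc2ccc(O)cc2)c2ncccc2c1` differs from compound 2 by one change, hydroxy in place of trifluoromethyl on an aromatic carbon. Among the measured compounds shown here, no measured step covers this exchange. For the measured compounds named here, the only step available, a 12-fold lower number from compound 1 to compound 2 (1.09 log units; beyond the scatter), is large but concerns a different change, so it bears only loosely. A smaller step is expected in this assay, probably towards a higher number. The expected step is a 1.8-fold higher number from compound 2 to compound 3 (0.26 log units; within the scatter). For compound 3 the estimated value is 15000 nM, within an expected range of 5000 nM to 50000 nM.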

Compound 3, half-maximal inhibitory concentration: 70000 nM
Estimate against measurement, compound 3: 4.7-fold (0.67 log units) below, and the stated range ends below it.
By their numbers in this assay, from the lowest: compound 2; then compounds 3 and 1 (each within the scatter of the next).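

In this assay, the place on the aromatic ring para to a large group proves sensitive to the group it carries: hydroxy in place of trifluoromethyl gives an 8.4-fold higher number from compound 2 to compound 3 (0.93 log units; beyond the scatter) with the rest of the molecule unchanged. The advantage of compound 2 does not carry over to every 4-substituted phenyl, since replacing ((4-bromophenyl)carbamoyl)amino with 4-hydroxyphenyl gives only a 1.4-fold lower number from compound 1 to compound 3 (0.16 log units; within the scatter) and leaves compound 3 level with compound 1. Nothing available accounts for this sensitivity. The compounds shown leave open whether an amine, a carboxylic acid or a methoxy group at this place would read closer to compound 2 or compound 3.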